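The compounds below may be only part of what the source reports. "The series", "measured", "known", "first", "only" and "open" are said of these compounds alone.

Compound 1 `CCC(C(=O)N1CCN(c2ccccc2F)CC1)N1C(=O)CCC1=O` and compound 2 `CCC(C(=O)N1CCN(c2cccc(C)c2)CC1)N1C(=O)CCC1=O` share one core and differ only in the aryl group on the ring amine nitrogen. In a functional assay on the whole organism (strain Swiss) with Mus musculus as the target, in the maximal electroshock model, with a stated time of 1 h, at a dose of 100 mg/kg by the intraperitoneal route (on this read-out higher numbers stand for a stronger effect at the one dose given and lower numbers for a weaker effect), compound 1 gives 0%, and in this assay compound 2 gives 0%. The step from one to the other is no change at the digits printed from compound 1 to compound 2 (within the scatter), so compound 2 stands level with compound 1 at the digits shown, and no compound of the pair can be called more or less active than the other.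

Compound 3 `CCC(C(=O)N1CCN(c2ccccc2)CC1)N1C(=O)CCC1=O` is the next member. Its difference from compound 2 is hydrogen in place of methyl on an aromatic carbon. Within the data shown here, the only measured step, no change at the digits printed from compound 1 to compound 2 (within the scatter), bears on it in that an exchange of the aryl group left the read-out unchanged; a smaller change at the same ring is therefore expected to produce no step beyond the scatter in this assay. The expected step is no change at the digits printed from compound 2 to compound 3 (within the scatter). Compound 3 is estimated to give 0%, with a range from 0% to 10%.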

Compound 3, a percentage reported as activity, at one dose (the size of the read-out at that dose, not a potency): 0%
Beside the measured number, compound 3's estimate shows no gap at the digits printed; measured number inside the range.
By their numbers in this assay, from the lowest: compounds 1, 2 and 3 (each within the scatter of the next).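

With compound 3 the unsubstituted phenyl enters the series as a reference, and hydrogen in place of methyl on an aromatic carbon gives no change at the digits printed from compound 2 to compound 3 (within the scatter). Hydrogen in place of fluoro on an aromatic carbon gives no change at the digits printed from compound 1 to compound 3 (within the scatter), so neither of these two groups separates from hydrogen in this assay. Since compound 3 also gives 0%, the series offers no read-out above that value against which a change at this ring could be sized. No evidence is available on what lies behind these values.

As far as these compounds go, it remains open whether a trifluoromethyl or methoxy group on the aromatic ring would give a different read-out in this assay. The same holds for a longer chain in place of the ethyl group on the shared core.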